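Chloro for trifluoromethyl on the amide aryl of compound 3

A few compounds are considered here, and "the series" means these few. Any claim that something is new, unique, unknown or untested is made for them only; others in the source may bear on it.

Compound 1 `Cc1ccc(S(=O)(=O)NCCCNc2nccc(-c3c(-c4cccc(F)c4)nc4sccn34)n2)cc1`: 9500 nM
Compound 2 `O=C(NCCCNc1nccc(-c2c(-c3cccc(F)c3)nc3sccn23)n1)c1ccc(F)cc1`: > 20000 nM (a limit)
Compound 3 `O=C(NCCNc1nccc(-c2c(-c3cccc(F)c3)nc3sccn23)n1)c1ccc(C(F)(F)F)cc1`: 9260 nM

In a functional assay on SK-MEL-28 cells (Homo sapiens) for cytotoxicity, read by MTT assay (on this read-out higher numbers stand for weaker inhibition and lower numbers for stronger inhibition), compound 3 gives 9260 nM, the lowest of the two numbers; compound 1 sits within the scatter of it. Compound 2 reaches only the limit (the limit of > 20000 nM in this assay, at which 1 of the 3 values shown sits). Compound 4 `O=C(NCCNc1nccc(-c2c(-c3cccc(F)c3)nc3sccn23)n1)c1ccc(Cl)cc1` differs from compound 3 by chloro in place of trifluoromethyl on an aromatic carbon. The one measured step, an at least 2.1-fold higher number from compound 1 to compound 2 (0.32 log units; beyond the scatter), exchanges the group on the amine nitrogen and does not touch the aromatic substituent, so no shown step bears on this change. With no guidance, the expected step of a 1.0-fold higher number from compound 3 to compound 4 (0.01 log units; within the scatter) is none beyond the scatter. Compound 4 is therefore expected to give about 9500 nM, between 4000 nM and 20000 nM.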

Compound 4, half-maximal inhibitory concentration: 8160 nM
For compound 4 the middle estimate is 1.2-fold (0.07 log units) above the measured one, within the range that was stated.
By their numbers in this assay, from the lowest: compounds 4, 3 and 1 (each within the scatter of the next). At a limit, above all of these: compound 2.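

In this assay, chloro in place of trifluoromethyl on this aromatic carbon gives a 1.1-fold lower number from compound 3 to compound 4 (0.05 log units; within the scatter), so this position accepts the exchange with no shift beyond the scatter. The wider exchanges give a 1.2-fold lower number from compound 1 to compound 4 (0.07 log units; within the scatter) and an at least 2.4-fold lower number from compound 2 to compound 4 (0.38 log units; beyond the scatter), but each alters the chain and the aryl group together. Compound 2 carries a limit, not a number: the limit of > 20000 nM in this assay, at which 1 of the 4 values shown sits.

On these data alone, whether an amine, a methoxy group or a carboxylic acid on this aromatic carbon would fit the same picture remains open. So does the effect of a longer chain on the 4-chlorophenyl amide alone.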